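One Nitro Group Removed in Two Related Pairs

The source may hold more compounds than are shown below. What is called first, only, known or untested is meant among the compounds shown, and "the series" means these compounds.

Compound 1 `O=C1C(Nc2ccccc2C(F)(F)F)=C(Nc2ccccc2C(F)(F)F)C(=O)c2c1cccc2[N+](=O)[O-]` and compound 3 `O=C1C(Nc2ccc(C(F)(F)F)cc2)=C(Nc2ccc(C(F)(F)F)cc2)C(=O)c2c1cccc2[N+](=O)[O-]` are built from the same atoms joined differently; the difference between the two cores is not broken down here. In an ADME assay on L6 cells (Rattus norvegicus) for cytotoxicity, read by sulforhodamine B assay, with a stated time of 72 h (a lower number here means a stronger inhibitor, a higher number a weaker inhibitor), compound 1 gives 88000 nM, and compound 3 gives 97000 nM. Compound 2 `O=C1C(Nc2ccc(C(F)(F)F)cc2)=C(Nc2ccc(C(F)(F)F)cc2)C(=O)c2ccccc21` differs from compound 3 by hydrogen in place of nitro on an aromatic carbon, and in this assay compound 2 gives 276000 nM, so that change gave a 2.8-fold higher number from compound 3 to compound 2 (0.45 log units; beyond the scatter). Compound 4 `O=C1C(Nc2ccccc2C(F)(F)F)=C(Nc2ccccc2C(F)(F)F)C(=O)c2ccccc21` differs from compound 1 by hydrogen in place of nitro on an aromatic carbon, the same change made at the same place. Resting on the earlier result of a 2.8-fold higher number from compound 3 to compound 2 (0.45 log units; beyond the scatter) and on compound 1 at 88000 nM, compound 4 is expected to show a 2.7-fold higher number from compound 1 to compound 4 (0.44 log units; beyond the scatter). Compound 4 is thus estimated at 240000 nM, most likely between 120000 nM and 500000 nM.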

Compound 4, half-maximal inhibitory concentration: 292000 nM
Beside the measured number, compound 4's estimate is 1.2-fold (0.09 log units) below it, and the stated range covers the measured number.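

In this assay, hydrogen in place of nitro gave a 3.3-fold higher number from compound 1 to compound 4 (0.52 log units; beyond the scatter). The step kept much the same size when carried from one core to the other, so in these two pairs the change can be transferred: the same change on two cores in this assay, a 2.8-fold higher number (0.45 log units; beyond the scatter) from compound 3 to compound 2 and a 3.3-fold higher number (0.52 log units; beyond the scatter) from compound 1 to compound 4, 1.2-fold (0.07 log units) apart, within the scatter of two such steps. Among the compounds shown here, this rests on only two pairs, both carrying trifluoromethyl groups, so it does not show that the step would hold on any other core, and it does not explain why the number rises once the nitro group is gone.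

The compounds shown leave open what an amine or a nitrile in place of the nitro group would give. They also leave open whether the step would keep its size with chlorine or a methoxy group in place of trifluoromethyl.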